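The source may hold more compounds than are shown below. What is called first, only, known or untested is meant among the compounds shown, and "the series" means these compounds.

Measured so far in a functional assay on HeLa cells (Homo sapiens) for cytotoxicity, read by MTT assay, with a stated time of 48 h; a lower number here means a stronger inhibitor, a higher number a weaker inhibitor:
compound 1, `CCCCCCCCCC(=O)N[C@@H](CCCNC(=N)N)C(=O)Nc1ccn([C@H]2O[C@@H](CO)[C@H](O)[C@H]2O)c(=O)n1`: 6000 nM
compound 2, `CCCCCCCCCCCCCCCCCC(=O)N[C@@H](CCCNC(=N)N)C(=O)Nc1ccn([C@H]2O[C@@H](CO)[C@H](O)[C@H]2O)c(=O)n1`: 12100 nM

Compound 1 is the reference point of the pair. Within the data shown here, its only measured neighbour is compound 2, and the step of a 2.0-fold higher number from compound 1 to compound 2 (0.30 log units; within the scatter) leaves the two indistinguishable; neither can be called the stronger inhibitor in this assay.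

Compound 3, `CCCCCCCCCC(=O)N[C@@H](CCSC)C(=O)Nc1ccn([C@H]2O[C@@H](CO)[C@H](O)[C@H]2O)c(=O)n1`, has not yet been measured. It keeps the acyl chain and the shared core of compound 1 and differs in the side chain of the amino acid: a group of 2 heavy atoms (1 carbon, 1 sulfur; no ring) in place of a group of 5 heavy atoms (2 carbon, 3 nitrogen; no ring), on a saturated chain carbon, three bonds along the chain from an amide-type nitrogen and a carbonyl carbon

Among the measured compounds shown here, the single measured step concerns a different place, the end of the acyl chain, and so does not bear on this change. For the measured compounds named here, no measured pair speaks to the exchange at the side chain, so there is no basis for expecting a shift in either direction beyond the scatter. For compound 3 the estimate in this assay is therefore set close to compound 1, at 8000 nM, with a range from 2500 nM to 25000 nM. The expected step is a 1.3-fold higher number from compound 1 to compound 3 (0.12 log units; within the scatter), and the wide range reflects that nothing measured constrains it.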

Compound 3, half-maximal inhibitory concentration: 3000 nM
Compound 3: middle estimate off by 2.7-fold (0.43 log units), on the high side, and the stated range covers the measured number.
By their numbers in this assay, from the lowest: compounds 3, 1 and 2 (each within the scatter of the next, the first and the last beyond it).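

In this assay, the exchange at the amino acid side chain, on a saturated chain carbon, three bonds along the chain from an amide-type nitrogen and a carbonyl carbon, gives a 2.0-fold lower number from compound 1 to compound 3 (0.30 log units; within the scatter). Among these compounds, this is the first reading at this position, and it shows that the group of 5 heavy atoms with 3 hydrogen-bond donors can give way to methylsulfanyl, with 0 hydrogen-bond donors, without a shift that can be told from the scatter, so neither side chain can be called the better one in this assay. Nothing available explains this outcome or links it to any property of either group.

From the compounds shown here alone, with only two side chains represented, it remains open whether an amine, a carboxylic acid or a plain butyl chain at this position would also stay within the scatter of compound 1. Also open, going by these compounds, is whether methylsulfanyl at this place would give a similar result when combined with the longer acyl chain of compound 2.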